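A few compounds are considered here, and "the series" means these few. Any claim that something is new, unique, unknown or untested is made for them only; others in the source may bear on it.

Measured so far: compound 1 `Cn1c(=O)[nH]c2c(cnn2-c2cccc(Br)c2)c1=N` gives 40% in an assay on membranes from brain for binding affinity to adenosine receptor A1 (Rattus norvegicus), read by radioligand binding, tested at 20 uM; a higher number here means more inhibition at the concentration tested (going by the name of the read-out), a lower number less inhibition; compound 2 `Cn1c(=O)[nH]c2c(cnn2-c2cccc(Cl)c2)c1=N` gives 53%; compound 3 `CCCCn1c(=O)[nH]c2c(cnn2-c2cccc(Cl)c2)c1=N` gives 58%.

Compound 2 stands second highest of these three numbers in this assay; the step of a number 5 percentage points higher from compound 2 to compound 3 (within the scatter) lies within the scatter, while the step of a number 13 percentage points higher from compound 1 to compound 2 (beyond the scatter) lies beyond it. Compound 4 `Cn1c(=O)[nH]c2c(cnn2-c2cccc(N)c2)c1=N` differs from compound 2 by amino in place of chloro on an aromatic carbon. Within the data shown here, only the change from compound 1 to compound 2 touches the same aromatic carbon, and that swap of one halogen for another moved the number by a number 13 percentage points higher from compound 1 to compound 2 (beyond the scatter); no measured compound replaces the halogen with amino. A modest step in this assay is therefore expected, more likely downward than upward, of about a number 11 percentage points lower from compound 2 to compound 4 (beyond the scatter). Compound 4 is estimated at 42%, between 22% and 62%.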

Compound 4, a percentage reported as inhibition, at one concentration (the size of the read-out at that concentration, not a potency): 0%
For compound 4 the middle estimate is 42 percentage points above the measured one, outside the stated range (below it).
By their numbers in this assay, from the lowest: compound 4; then compound 1; then compounds 2 and 3 (each within the scatter of the next).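

In this assay this aromatic carbon proves far less forgiving than the swap between halogens suggested: amino in place of chloro gives a number 53 percentage points lower from compound 2 to compound 4 (beyond the scatter), and amino in place of bromo gives a number 40 percentage points lower from compound 1 to compound 4 (beyond the scatter). Both steps are large, whereas the change between the two halogens was modest, so the identity of the group here can matter much more than that change showed. Nothing available accounts for this loss.

As far as these compounds go, whether a hydroxyl or a methoxy group on this carbon would fall as far as amino stays open. So does whether amino would give the same loss alongside the longer chain of compound 3.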